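This account rests on a few compounds, and the source may have more. Where it says the series, first, only, none or still open, it means among the compounds named here.

In a functional assay on A2780 cells (Homo sapiens) for antiproliferative activity, read by CellTiter-Glo, with a stated time of 4 days (a higher number here means a weaker inhibitor, a lower number a stronger inhibitor), compound 2 `O=C(N[C@@H](CO)c1ccc(NC(=O)[C@H]2C[C@@H]2c2cccnc2)cc1)c1ccccc1` gives 200 nM. Among the compounds with values here, this is the only number so far, so it cannot yet be ranked as strong or weak against anything else. Compound 1 `O=C(/C=C/c1cccnc1)Nc1ccc(CN2C(=O)c3ccccc3C2=O)cc1` offers no comparison, since the entry for compound 1 reads "not determined" (no result reported).

Compound 3 `C[C@H](NC(=O)c1ccccc1)c1ccc(NC(=O)[C@H]2C[C@@H]2c2cccnc2)cc1` differs from compound 2 in one place: hydrogen in place of hydroxy on a saturated chain carbon, two bonds along the chain from an amide-type nitrogen and an aromatic carbon. This puts hydrogen in place of hydroxy on a saturated chain carbon, two bonds along the chain from an amide-type nitrogen and an aromatic carbon, so hydroxymethyl becomes methyl.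

Within the data shown here, no measured pair shows what such a change does in this assay, so any prediction is a judgement. A modest move towards a lower number, meaning a stronger inhibitor, is expected, though a result within the usual scatter would be unsurprising. The estimated change is a 2.9-fold lower number from compound 2 to compound 3 (0.46 log units; beyond the scatter). For compound 3 the expected value is 70 nM, with an estimated range of 15 nM to 250 nM.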

Compound 3, half-maximal inhibitory concentration: 1 nM
Estimate against measurement, compound 3: 70-fold (1.85 log units) above; the measured number lies below the stated range.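

At this saturated chain carbon, two bonds along the chain from an amide-type nitrogen and an aromatic carbon, the change from hydroxymethyl to methyl matters greatly in this assay, giving a 200-fold lower number from compound 2 to compound 3 (2.30 log units; beyond the scatter). Within the data shown here, removing one oxygen atom, and with it one hydrogen-bond donor and one acceptor, is therefore enough to shift the result strongly, which the single value for compound 2 could not reveal. Nothing available here explains why this small change has so large an effect.

Still open, as far as these compounds go, is whether methyl itself is the best group here, or whether an ethyl group, a longer chain, an amine or a carboxylic acid at this carbon would give a higher or lower number. This single pair also cannot show whether the same change would have a similar effect on a different core.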